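The compounds below may be only part of what the source reports. "The series", "measured", "known", "first", "only" and "open" are said of these compounds alone.

Measured so far: compound 1 `CCN(CC)CC(=O)OC1CC2(N3CCCCC3)CC(c3ccccc3)C1C(c1ccccc1)C2` gives 23900 nM; compound 2 `CN1CCN(CC(=O)N2CCC3(N4CCCCC4)CC(c4ccccc4)C2C(c2ccccc2)C3)CC1` gives 177000 nM; compound 3 `CCN(CC)CC(=O)OC1CC2(N3CCCC3)CC(c3ccccc3)C1C(c1ccccc1)C2` gives 49000 nM.

All three numbers come from an ADME assay on L6 cells (Rattus norvegicus) for cytotoxicity, read by resazurin assay, with a stated time of 72 h; on this read-out lower numbers stand for stronger inhibition and higher numbers for weaker inhibition. Compound 3 differs from compound 1 by pyrrolidin-1-yl in place of piperidin-1-yl on a saturated ring carbon, a change that gave a 2.1-fold higher number from compound 1 to compound 3 (0.31 log units; beyond the scatter). How the core of compound 2 differs from that of compound 1 is not broken down here; compound 2 gives the highest number of the three. Compound 4 `CN1CCN(CC(=O)N2CCC3(N4CCCC4)CC(c4ccccc4)C2C(c2ccccc2)C3)CC1` is not yet measured. It differs from compound 2 by pyrrolidin-1-yl in place of piperidin-1-yl on a saturated ring carbon, the same kind of change, though the surroundings differ: in compound 1 the ring carbon sits by a ring atom that bears a (((diethylamino)methyl)carbonyl)oxy group, in compound 2 by two ring atoms that each bear a phenyl group. A step of about a 1.9-fold higher number from compound 2 to compound 4 (0.27 log units; within the scatter) is expected, resting on a 2.1-fold higher number from compound 1 to compound 3 (0.31 log units; beyond the scatter). Compound 4 is therefore estimated at 330000 nM, likely between 150000 nM and 800000 nM.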

Compound 4, half-maximal inhibitory concentration: 69100 nM
Beside the measured number, compound 4's estimate is 4.8-fold (0.68 log units) above it; measured number below the stated range.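

In this assay, putting pyrrolidin-1-yl in place of piperidin-1-yl gave a 2.6-fold lower number from compound 2 to compound 4 (0.41 log units; beyond the scatter), so the change did not run the same way as it did on the core of compound 1. The two results point in opposite directions, and the gap between them is larger than repeat measurements would explain: the same change on two cores in this assay, a 2.1-fold higher number (0.31 log units; beyond the scatter) from compound 1 to compound 3 and a 2.6-fold lower number (0.41 log units; beyond the scatter) from compound 2 to compound 4, 5.3-fold (0.72 log units) apart, beyond the scatter of two such steps. This shows that a step measured on one core cannot simply be carried over to the other, but two pairs do not show which structural difference between the cores matters or what a further core would do.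

Open, as far as these compounds go, is how a morpholin-4-yl or dimethylamino group would behave at this ring carbon on either core. Also open, from the compounds shown here alone, is whether a diethylamino side chain on the core of compound 2 would change the direction of the step.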